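Swapping the Aryl Group on the Amide Nitrogen

The source may report more compounds than this note shows. Statements on the series, on what has been measured and on what is new or still open speak of the compounds shown alone.

Measured so far:
compound 1 `O=C(Nc1ccccc1)c1ccc(/N=N\c2c[nH]c3ccccc23)cc1` gives 147000 nM in a functional assay on MCF7 cells (Homo sapiens) for inhibition, read by MTT assay, with a stated time of 72 h; a lower number here means a stronger inhibitor, a higher number a weaker inhibitor
compound 2 `O=C(Nc1ccccc1F)c1ccc(/N=N\c2c[nH]c3ccccc23)cc1` gives 83800 nM in this assay

Within the data shown here, compound 2 shows the lower of the two numbers, but the only measured step, a 1.8-fold lower number from compound 1 to compound 2 (0.24 log units; within the scatter), lies within the scatter, so the two compounds cannot be told apart on this evidence. Compound 3 `O=C(Nc1ccc(Cl)cc1)c1ccc(/N=N\c2c[nH]c3ccccc23)cc1` differs from compound 2 by 4-chlorophenyl in place of 2-fluorophenyl on an amide-type nitrogen. Among the measured compounds shown here, no measured pair shares this change. For the measured compounds named here, the single step known so far also put a halogen onto the same aryl group and stayed within the scatter, which gives no ground for expecting a shift in either direction here. The number for compound 3 in this assay is therefore expected to sit close to that of compound 2, an estimated step of a 1.0-fold lower number from compound 2 to compound 3 (0.02 log units; within the scatter). Compound 3 is estimated at 80000 nM, with a range from 30000 nM to 200000 nM.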

Compound 3, half-maximal inhibitory concentration: 107000 nM
Beside the measured number, compound 3's estimate is 1.3-fold (0.13 log units) below it, and the stated range covers the measured number.
By their numbers in this assay, from the lowest: compounds 2, 3 and 1 (each within the scatter of the next).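

Exchanging 2-fluorophenyl for 4-chlorophenyl on the amide-type nitrogen gives a 1.3-fold higher number from compound 2 to compound 3 (0.11 log units; within the scatter) in this assay, while adding a chloro group to the unsubstituted aryl ring gives a 1.4-fold lower number from compound 1 to compound 3 (0.14 log units; within the scatter) in the same assay. With a second halogen and a second ring position now tested, compound 1, compound 2 and compound 3 still cannot be told apart, so neither halogen has yet moved the number beyond the scatter. No measurement shown here accounts for how close these numbers lie.

The step between compound 2 and compound 3 changes the halogen and its place together, so the two changes cannot be separated. On these data alone, whether a non-halogen group on this aryl ring, such as an amine or a carboxylic acid, or a longer chain in place of the ring, would shift the number remains open.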